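2-Nitrophenyl in Place of 4-Fluorophenyl: An Estimate

The source may report more compounds than this note shows. Statements on the series, on what has been measured and on what is new or still open speak of the compounds shown alone.

Measured compounds:
compound 1, `Cc1ccc(N2CCN(C(=S)N/N=C3\C(=O)Nc4ccc(Cl)cc43)CC2)cc1`, which in a functional assay on MCF7 cells (Homo sapiens) for inhibition, read by MTT assay, with a stated time of 72 h (on this read-out higher numbers stand for weaker inhibition and lower numbers for stronger inhibition), gives 17100 nM
compound 2, `O=C1Nc2ccc(Cl)cc2/C1=N/NC(=S)N1CCN(c2ccc(F)cc2)CC1`, which in this assay gives 12300 nM

For the measured compounds named here, compound 2 holds the lowest of the two numbers, yet the one measured step, a 1.4-fold lower number from compound 1 to compound 2 (0.14 log units; within the scatter), is within the scatter, so the two cannot be ordered. Compound 3, `O=C1Nc2ccc(Cl)cc2/C1=N/NC(=S)N1CCN(c2ccccc2[N+](=O)[O-])CC1`, differs from compound 2 by 2-nitrophenyl in place of 4-fluorophenyl on an amine nitrogen in a ring. Going by the values given here, that single step bears only loosely on this change, since it also altered the group on the same ring nitrogen and moved nothing beyond the scatter; no other step exists. Compound 3 is therefore expected to show a 1.0-fold lower number from compound 2 to compound 3 (0.01 log units; within the scatter), a change within the scatter. The estimate for compound 3 is 12000 nM, with a range from 4000 nM to 40000 nM.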

Compound 3, half-maximal inhibitory concentration: 7490 nM
Estimate against measurement, compound 3: 1.6-fold (0.20 log units) above; the measured number falls inside the stated range.
By their numbers in this assay, from the lowest: compounds 3, 2 and 1 (each within the scatter of the next, the first and the last beyond it).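

In this assay, 2-nitrophenyl in place of 4-fluorophenyl gives a 1.6-fold lower number from compound 2 to compound 3 (0.22 log units; within the scatter), so this exchange cannot be told apart from scatter. For the compounds shown here, in place of 4-methylphenyl, the same group gives a 2.3-fold lower number from compound 1 to compound 3 (0.36 log units; beyond the scatter), the only step here beyond the scatter, which shows that the number at this ring nitrogen can shift, if modestly. Nothing measured here accounts for that shift. Still open, from the compounds shown here alone, is how an unsubstituted phenyl, a benzyl group or an aminophenyl on this nitrogen would read, and whether a carboxylic acid on the phenyl ring would move the number further.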